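N-Methyl to Hydrogen on Two Different Amide Nitrogens

The source may hold more compounds than are shown below. What is called first, only, known or untested is meant among the compounds shown, and "the series" means these compounds.

Measured compounds:
compound 1 `CC(=O)N1CCC(C(=O)N2CC[C@@H](C(=O)N(C)Cc3cc(C(F)(F)F)cc(C(F)(F)F)c3)[C@H](c3ccccc3)C2)CC1`, 0.098 nM
compound 2 `CC(=O)N1CCC(C(=O)N2CC[C@@H](C(=O)NCc3cc(C(F)(F)F)cc(C(F)(F)F)c3)[C@H](c3ccccc3)C2)CC1`, 2.7 nM
compound 3 `CNC(=O)N1CC[C@H](C(=O)N(C)Cc2cc(C(F)(F)F)cc(C(F)(F)F)c2)[C@@H](c2ccc(F)cc2C)C1`, 0.048 nM

In an assay on IM-9 cells for displacement of a labelled ligand from Substance-P receptor (Homo sapiens), read by scintillation counting, with a stated time of 30 min (on this read-out lower numbers stand for stronger inhibition and higher numbers for weaker inhibition), compound 3 gives the lowest number of the three, with compound 1 nearest and compound 2 furthest. Compound 1 and compound 2 share a core and differ in one place: hydrogen in place of methyl on an amide-type nitrogen. That change gave a 28-fold higher number from compound 1 to compound 2 (1.44 log units; beyond the scatter). Compound 4 `Cc1cc(F)ccc1[C@H]1CN(C(N)=O)CC[C@@H]1C(=O)N(C)Cc1cc(C(F)(F)F)cc(C(F)(F)F)c1` is not yet measured; it differs from compound 3 by hydrogen in place of methyl on an amide-type nitrogen. The difference between the core of compound 3 and the core of compound 1 is not broken down here.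

The two changes are the same kind of change, not the same one. Among the compounds with values here, in compound 2 the altered nitrogen has a carbonyl carbon and a saturated chain carbon as its other neighbours, whereas in compound 4 its only other neighbour is a carbonyl carbon, so the methyl is lost from a methylcarbamoyl group, giving carbamoyl. Because of a 28-fold higher number from compound 1 to compound 2 (1.44 log units; beyond the scatter) a weaker result is expected for compound 4 in this assay, but the different surroundings leave the size uncertain, so a smaller step is estimated: a 2.5-fold higher number from compound 3 to compound 4 (0.40 log units; beyond the scatter). Compound 4 is expected to give 0.12 nM, between 0.03 nM and 0.5 nM.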

Compound 4, half-maximal inhibitory concentration: 0.035 nM
The estimate for compound 4 lay 3.4-fold (0.54 log units) above the measured number, and the stated range covers the measured number.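

In this assay, hydrogen in place of methyl on the methylcarbamoyl nitrogen gave a 1.4-fold lower number from compound 3 to compound 4 (0.14 log units; within the scatter), so the loss seen on the other core did not appear here, and compound 3 and compound 4 cannot be told apart. The same kind of change therefore did not carry over from one core to the other, and the two steps differ by more than the scatter: the same change on two cores in this assay, a 28-fold higher number (1.44 log units; beyond the scatter) from compound 1 to compound 2 and a 1.4-fold lower number (0.14 log units; within the scatter) from compound 3 to compound 4, 38-fold (1.58 log units) apart, beyond the scatter of two such steps What this does not show is which difference is responsible, as the two altered nitrogens have different surroundings and the cores differ as well, and two pairs give no rule for any further core.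

The compounds shown leave open whether the core of compound 3 would also tolerate hydrogen in place of methyl on the amide nitrogen altered in compound 2. They also leave open how an ethyl group or a longer chain on the carbamoyl nitrogen of compound 4 would read in this assay.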